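Amide-side ring substituent change and reductase inhibition

A few compounds are considered here, and "the series" means these few. Any claim that something is new, unique, unknown or untested is made for them only; others in the source may bear on it.

Measured so far in an assay on microsomes from liver for inhibition of 3-hydroxy-3-methylglutaryl-coenzyme A reductase (Rattus norvegicus); on this read-out lower numbers stand for stronger inhibition and higher numbers for weaker inhibition:
compound 1 `CC(C)c1c(C(=O)N(C)Cc2ccccc2)nn(-c2ccc(F)cc2)c1OC[C@@H](O)C[C@@H](O)CC(=O)O`: 5.2 nM
compound 2 `Cc1ccc(CN(C)C(=O)c2nn(-c3ccc(F)cc3)c(OC[C@@H](O)C[C@@H](O)CC(=O)O)c2C(C)C)cc1`: 37 nM
compound 3 `COc1cccc(CNC(=O)c2nn(-c3ccc(F)cc3)c(OC[C@@H](O)C[C@@H](O)CC(=O)O)c2C(C)C)c1`: 16 nM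

Compound 3 stands second highest of the three numbers: its nearest neighbour is compound 2, as a 2.3-fold lower number from compound 2 to compound 3 (0.36 log units; beyond the scatter) shows, and its furthest is compound 1, as a 3.1-fold higher number from compound 1 to compound 3 (0.49 log units; beyond the scatter) shows. Both steps are beyond the scatter but modest.

Compound 4 `COCc1cccc(CNC(=O)c2nn(-c3ccc(F)cc3)c(OC[C@@H](O)C[C@@H](O)CC(=O)O)c2C(C)C)c1` differs from compound 3 by methoxymethyl in place of methoxy on an aromatic carbon. Within the data shown here, no measured step touches a substituent at this place on the ring of the benzyl group. Among the measured compounds shown here, the steps that bear on it only loosely are a 7.1-fold higher number from compound 1 to compound 2 (0.85 log units; beyond the scatter), where a methyl enters on an aromatic carbon of that ring, and a 2.3-fold lower number from compound 2 to compound 3 (0.36 log units; beyond the scatter), where the ring substituent and the amide nitrogen change together. Both are modest, and neither isolates the effect of lengthening a substituent on this ring by one carbon. The expectation for this assay is therefore a small step, within or just beyond the scatter, with a slight lean toward a higher number, which is weaker inhibition.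

Compound 4 is expected to give 22 nM in this assay, within 8 nM to 60 nM, meaning an expected step of a 1.4-fold higher number from compound 3 to compound 4 (0.14 log units; within the scatter).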

Compound 4, half-maximal inhibitory concentration: 31 nM
Compound 4: the middle estimate sits 1.4-fold (0.15 log units) below what was measured; low and high end bracket the measured number.
By their numbers in this assay, from the lowest: compound 1; then compounds 3, 4 and 2 (each within the scatter of the next, the first and the last beyond it).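

In this assay, among these compounds, methoxymethyl in place of methoxy on an aromatic carbon meta to a large group gives a 1.9-fold higher number from compound 3 to compound 4 (0.29 log units; within the scatter) and so offers the first direct reading at this place on the ring, where one added carbon in the substituent cannot be told from the scatter. Set against methyl(4-methylbenzyl)amino, the (3-(methoxymethyl)benzyl)amino group gives a 1.2-fold lower number from compound 2 to compound 4 (0.08 log units; within the scatter) and again cannot be told apart, while set against benzyl(methyl)amino it gives a 6.0-fold higher number from compound 1 to compound 4 (0.78 log units; beyond the scatter) and remains a modest step beyond the scatter. Nothing at hand accounts for where these numbers fall.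

The compounds shown leave open how a hydroxymethyl, an aminomethyl or a carboxylic acid at this place would read in this assay, and whether a longer chain such as methoxyethyl would move the number beyond the scatter. Also open, going by these compounds, is whether methoxymethyl at this place would read the same with a methyl on the amide nitrogen, as that change has only been seen here together with a change on the ring.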